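The source may report more compounds than this note shows. Statements on the series, on what has been measured and on what is new or still open speak of the compounds shown alone.

Measured in an assay on 32D cells for inhibition of interleukin-15 (Mus musculus), read by resazurin assay, with stated times of 30 min and 2.5 days, in the presence of a further agent that is not named here; on this read-out higher numbers stand for weaker inhibition and lower numbers for stronger inhibition:
compound 1 `Cn1c(Cc2nn(C)c(=O)c3ccccc23)nnc1SCCCCCCCC(=O)Nc1ccc(Cl)cc1Cl`: 2200 nM
compound 2 `Cn1nc(Cc2nnc(SCCCCCCCC(=O)Nc3ccc(Cl)cc3Cl)n2CCC=O)c2ccccc2c1=O`: 2500 nM
compound 3 `Cn1nc(Cc2nnc(SCCCCCCCC(=O)Nc3ccc(Cl)cc3Cl)n2CCCO)c2ccccc2c1=O`: > 30000 nM, a limit of this assay (the limit of > 30000 nM in this assay, at which 1 of the 3 values shown sits)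

Compound 1 holds the lowest of the two numbers given; compound 2 sits within the scatter of it, a 1.1-fold higher number from compound 1 to compound 2 (0.06 log units; within the scatter). Compound 4 `Cn1c(Cc2nn(CCC(=O)O)c(=O)c3ccccc23)nnc1SCCCCCCCC(=O)Nc1ccc(Cl)cc1Cl` differs from compound 1 by carboxymethyl in place of hydrogen on a saturated chain carbon bound to an aromatic nitrogen. Two measured steps at the same place bear on this change and point in opposite directions: a 1.1-fold higher number from compound 1 to compound 2 (0.06 log units; within the scatter), and an at least 13-fold higher number from compound 1 to compound 3 (1.13 log units; beyond the scatter), the latter ending at a limit. The comparison an at least 12-fold higher number from compound 2 to compound 3 (1.07 log units; beyond the scatter) shows how sharply the outcome turns on the group at the chain end. Carboxymethyl matches neither precedent, so a moderate loss is expected, a 3.2-fold higher number from compound 1 to compound 4 (0.50 log units; beyond the scatter), with wide uncertainty. Compound 4 is estimated at 7000 nM in this assay, between 2000 nM and 30000 nM.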

Compound 4, half-maximal inhibitory concentration: > 30000 nM
Compound 4: no number, only a limit; the forecaster's own chance of this, stated with the estimate: 30%; at least 4.2-fold (0.63 log units) between middle value and limit.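

Carboxymethyl gives an at least 13-fold higher number from compound 1 to compound 4 (1.13 log units; beyond the scatter) in this assay, so a second extension of this chain now ends far from compound 1. Going by these compounds, compound 4 reads only as a limit, not a number, and the true size of its step stays unknown: the limit of > 30000 nM in this assay, at which 2 of the 4 values shown sit. Two of the three extended chains now sit at that limit, and compound 2 is the one that goes against this pattern.

On these data alone, whether a methyl ester or an amine at the chain end, or a longer chain, would stay close to compound 1 remains open. As far as these compounds go, how much weaker compound 3 and compound 4 really are also remains open.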